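A few compounds are considered here, and "the series" means these few. Any claim that something is new, unique, unknown or untested is made for them only; others in the source may bear on it.

Measured so far in a functional assay on NCI-H23 cells (Homo sapiens) for antiproliferative activity, read by sulforhodamine B assay; a lower number here means a stronger inhibitor of growth, a higher number a weaker inhibitor of growth:
Compound 1 `COc1cccc(OCCC(C)(C)C)c1C(=O)/C=C/c1ccc(O)cc1`: > 30000 nM, a limit.
Compound 2 `O=C(/C=C/c1ccc(O)cc1)c1c(O)cccc1OCCC1CCCCC1`: > 30000 nM, a limit.

Compound 2 stands at a limit and has no number of its own. Within the data shown here, the whole picture in this assay so far is the limit of > 30000 nM in this assay, at which 2 of the 2 values shown sit. Among the measured compounds shown here, no step between measured compounds is available, so the series gives no measured size of change to work from.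

Compound 3 `CC(C)COc1cccc(O)c1C(=O)/C=C/c1ccc(O)cc1` is the next to be read. Its difference from compound 2 is isopropyl in place of cyclohexylmethyl on a saturated chain carbon bound to an oxygen on an aromatic ring. In short, the 2-cyclohexylethoxy gives way to isobutoxy, with the rest of the structure unchanged.

A modest step toward stronger growth inhibition is expected, and a further reading at the limit would be no surprise. The expectation rests only on this structural change and on compound 2 at > 30000 nM, a limit. The estimated change is an at least 1.6-fold lower number from compound 2 to compound 3 (0.22 log units; that floor lies within the scatter). Compound 3 is expected at 18000 nM, with an estimated range from 5000 nM to 30000 nM.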

Compound 3, concentration for 50% growth inhibition: 3220 nM
The estimate for compound 3 lay 5.6-fold (0.75 log units) above the measured number, outside the stated range (below it).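

Among these compounds, compound 3 is the first compound with a number of its own in this assay, and it shows that growth inhibition responds to the group carried on this oxygen: isobutoxy in place of 2-cyclohexylethoxy gives an at least 9.3-fold lower number from compound 2 to compound 3 (0.96 log units; beyond the scatter). Among the compounds shown here, the change removes the six-membered carbon ring and shortens the group from 7 to 3 heavy atoms in a single step, and the single pair cannot separate these two differences. The size of the step remains a floor, and the series still rests mostly on one ceiling: the limit of > 30000 nM in this assay, at which 2 of the 3 values shown sit.

From the compounds shown here alone, it remains open whether the ring itself or only the total size of the group separates compound 2 from compound 3, a question that an unbranched chain such as n-hexyloxy or a smaller ethoxy group at the same place would address. Also open, going by these compounds, is how far the response extends to groups of a different kind, such as a chain ending in an amine or a carboxylic acid, and whether the free hydroxyl of compound 3 contributes to its value, since no single-place comparison of hydroxyl and methoxy is available here.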